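A few compounds are considered here, and "the series" means these few. Any claim that something is new, unique, unknown or untested is made for them only; others in the source may bear on it.

Measured so far in a functional assay on GTL 16 cells for antiproliferative activity against GTL 16 cell line (Homo sapiens), read by CCK-8 assay, with a stated time of 72 h; on this read-out higher numbers stand for weaker inhibition and lower numbers for stronger inhibition:
compound 1, `COc1ccc(C(=O)Nc2cccc(-c3oc4cc(-c5ccc(F)cc5)ccc4c(=O)c3O)c2)cc1`, gives 21100 nM
compound 2, `Cc1ccc(C(=O)Nc2cccc(-c3oc4cc(-c5ccc(F)cc5)ccc4c(=O)c3O)c2)cc1`, gives 12900 nM
compound 3, `Cc1cc(C(=O)Nc2cccc(-c3oc4cc(-c5ccc(F)cc5)ccc4c(=O)c3O)c2)ccc1F`, gives 12100 nM

All three share one core and differ only in the aryl group attached to the amide carbonyl. Compound 1 has the highest of the three numbers, but its distances to the others are small: a 1.6-fold lower number from compound 1 to compound 2 (0.21 log units; within the scatter) and a 1.7-fold lower number from compound 1 to compound 3 (0.24 log units; within the scatter) both lie within the scatter, as does a 1.1-fold lower number from compound 2 to compound 3 (0.03 log units; within the scatter). So far, changing the substituent on that outer ring has not moved the numbers beyond what repeated measurement would show.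

Compound 4, `N#Cc1ccc(C(=O)Nc2cccc(-c3oc4cc(-c5ccc(F)cc5)ccc4c(=O)c3O)c2)cc1`, has not yet been measured. It differs from compound 1 in one place: cyano in place of methoxy on an aromatic carbon. Among the compounds with values here, no measured step introduces a cyano group, so the closest guides are the two steps from compound 1, both small. On that basis no step beyond the scatter is expected in this assay, with at most a slight lowering of the number. The expected step is a 1.4-fold lower number from compound 1 to compound 4 (0.15 log units; within the scatter). Compound 4 is therefore estimated at 15000 nM, within 6000 nM to 40000 nM.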

Compound 4, half-maximal inhibitory concentration: 31800 nM
The estimate for compound 4 lay 2.1-fold (0.33 log units) below the measured number; low and high end bracket the measured number.
By their numbers in this assay, from the lowest: compounds 3, 2, 1 and 4 (each within the scatter of the next, the first and the last beyond it).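

In this assay, this position on the outer ring now shows steps beyond the scatter, both modest and both ending at the 4-cyanophenyl group of compound 4 (a 2.6-fold higher number from compound 3 to compound 4 (0.42 log units; beyond the scatter) and a 2.5-fold higher number from compound 2 to compound 4 (0.39 log units; beyond the scatter)). The same cyano group in place of methoxy stays within the scatter (a 1.5-fold higher number from compound 1 to compound 4 (0.18 log units; within the scatter)), so the size of the step depends on which compound serves as the reference, and compound 1 and compound 4 cannot be told apart. Nothing available here explains why cyano gives these steps.

From the compounds shown here alone, whether an amine or a carboxylic acid at this place on the ring, or a longer chain such as butoxy, would shift the number further remains open. Going by these compounds, the shared core is the same in all four compounds, so the effect of changes there also remains open.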